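This account rests on a few compounds, and the source may have more. Where it says the series, first, only, none or still open, it means among the compounds named here.

Working notes on the series. Compound 1 `COc1ccc(Nc2ncc3c(n2)N(C2CCCC2)CC(=O)N3C)cc1` and compound 2 `CCN1C(=O)CN(C2CCCC2)c2nc(Nc3ccc(OC)cc3)ncc21` share one core; compound 3 `CN1CCN(c2ccc(Nc3ncc4c(n3)N(C3CCCC3)CC(=O)N4C)nc2)CC1` carries a different one, and the difference between the two cores is not broken down here. In a functional assay on MDA-MB-231 cells (Homo sapiens) for inhibition, read by MTT assay, with a stated time of 48 h (a higher number here means a weaker inhibitor, a lower number a stronger inhibitor), compound 1 reaches only the assay limit, > 30000 nM. In this assay compound 2 likewise stops at the limit, > 30000 nM. The change between them, (methyl in place of hydrogen on a saturated chain carbon bound to an amide-type nitrogen in a ring), gives a step that the two limits leave unreadable from compound 1 to compound 2, since both values sit at the limit of > 30000 nM in this assay, at which 2 of the 3 values shown sit. Among the compounds with values here, compound 3 is the only one with a number in this assay, 23700 nM. Compound 4 `CCN1C(=O)CN(C2CCCC2)c2nc(Nc3ccc(N4CCN(C)CC4)cn3)ncc21` is not yet measured; it arises from compound 3 by methyl in place of hydrogen on a saturated chain carbon bound to an amide-type nitrogen in a ring, the same change as from compound 1 to compound 2. That earlier step is unreadable, so only a small step is expected, a 1.1-fold higher number from compound 3 to compound 4 (0.02 log units; within the scatter), for compound 4. In this assay compound 4 is estimated at 25000 nM, between 9000 nM and 30000 nM.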

Compound 4, half-maximal inhibitory concentration: 24100 nM
Beside the measured number, compound 4's estimate is 1.0-fold (0.02 log units) above it; the range from low to high includes it.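

In this assay, methyl in place of hydrogen on a saturated chain carbon bound to an amide-type nitrogen in a ring gives a 1.0-fold higher number from compound 3 to compound 4 (0.01 log units; within the scatter) on the core of compound 3. The same change on the core of compound 1 cannot be read, because compound 1 and compound 2 are both assay limits and not numbers: the limit of > 30000 nM in this assay, at which 2 of the 4 values shown sit. The pair on the core of compound 3 is thus the only readable case, and it does not show that the change carries over from one core to the other in the same way.

Open, as far as these compounds go, is whether propyl, a longer chain than ethyl, or an amine or a carboxylic acid on that carbon would give a step beyond the scatter. Also open, from the compounds shown here alone, is how the change reads in compounds with numbers far from the limit.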